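The source may hold more compounds than are shown below. What is called first, only, known or untested is meant among the compounds shown, and "the series" means these compounds.

Compound 2 `COc1cccc(/C=C2\CCC/C(=C\c3cccc(Cl)c3Cl)C2=O)c1OC` in a functional assay on HT-1080 cells (Homo sapiens) for cytotoxicity, read by MTT assay, with a stated time of 72 h (a higher number here means a weaker inhibitor, a lower number a stronger inhibitor), gives 19300 nM; compound 1 `COc1cccc(/C=C2\CCC/C(=C\c3ccc(Br)cc3)C2=O)c1OC` gives 13700 nM, the pair separated only by a 1.4-fold higher number from compound 1 to compound 2 (0.15 log units; within the scatter), which lies within the scatter. Compound 3 `COc1cccc(/C=C2\CCC/C(=C\c3ccc(O)c(O)c3)C2=O)c1OC` differs from compound 2 by 3,4-dihydroxyphenyl in place of 2,3-dichlorophenyl on a double-bonded chain carbon bound to a double-bonded ring carbon. For the measured compounds named here, the single measured step exchanges one halogenated phenyl for another and shows no movement; no measured pair exchanges halogen for hydroxyl, so that step is only a loose guide here. The step expected is a 1.0-fold higher number from compound 2 to compound 3 (0.02 log units; within the scatter), with no direction favoured beyond the scatter. Compound 3 is estimated at 20000 nM, range 7000 nM to 60000 nM.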

Compound 3, half-maximal inhibitory concentration: 4700 nM
Beside the measured number, compound 3's estimate is 4.3-fold (0.63 log units) above it, and the stated range ends above it.
By their numbers in this assay, from the lowest: compound 3; then compounds 1 and 2 (each within the scatter of the next).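

In this assay, the swap between halogenated phenyl groups on a double-bonded chain carbon bound to a double-bonded ring carbon had moved nothing beyond the scatter, but 3,4-dihydroxyphenyl does: a 4.1-fold lower number from compound 2 to compound 3 (0.61 log units; beyond the scatter) and a 2.9-fold lower number from compound 1 to compound 3 (0.46 log units; beyond the scatter) are both beyond it. The number at this place therefore depends on the group carried, and compound 3 stands lowest of the three. No evidence on the cause is at hand. As far as these compounds go, whether both hydroxyl groups are needed remains open, as a single hydroxyl would test. From the compounds shown here alone, an amine or a carboxylic acid on this phenyl ring also remains untested here.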